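Methyl for Hydrogen on the Aryl Ring of Compound 2

This account rests on a few compounds, and the source may have more. Where it says the series, first, only, none or still open, it means among the compounds named here.

Measured so far:
compound 1 `O=C(O)CCC1=C(c2ccc(Cl)cc2)NC(=S)NC1c1ccco1` gives 30.4% in a functional assay on the whole organism (strain Albino) for inhibition, with Rattus norvegicus as the target, with a stated time of 1 h, at a dose of 20 mg/kg by the oral route; a higher number here means more inhibition at the dose given (going by the name of the read-out), a lower number less inhibition
compound 2 `O=C(O)CCC1=C(c2ccccc2)NC(=S)NC1c1ccco1` gives 28.8% in this assay

Among the two numbers at hand compound 2 stands lowest, though its only neighbour is compound 1, and the single known gap, a number 1.6 percentage points lower from compound 1 to compound 2 (within the scatter), lies within the scatter, so the two compounds cannot be ordered on this evidence.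

Compound 3 `Cc1ccc(C2=C(CCC(=O)O)C(c3ccco3)NC(=S)N2)cc1` has not yet been measured in this assay. It differs from compound 2 by methyl in place of hydrogen on an aromatic carbon. Within the data shown here, the only measured step, a number 1.6 percentage points lower from compound 1 to compound 2 (within the scatter), exchanged chloro for hydrogen on an aromatic carbon and moved the number by no more than the scatter; it bears on the new change only in showing that a substituent change on an aromatic carbon of this ring made little difference. Among the measured compounds shown here, no step involving a methyl has been measured. Compound 3 is therefore expected to sit close to compound 2, with an estimated step of a number 1.2 percentage points higher from compound 2 to compound 3 (within the scatter), not beyond the scatter in either direction. Compound 3 is estimated at 30%, within 18% to 42%.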

Compound 3, a percentage reported as inhibition, in the whole organism at one dose (the size of the read-out at that dose, not a potency): 33%
The estimate for compound 3 lay 3 percentage points below the measured number, within the range that was stated.
By their numbers in this assay, from the lowest: compounds 2, 1 and 3 (each within the scatter of the next).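

In this assay, methyl in place of hydrogen on this aromatic carbon, para to a large group, comes out as a number 4.2 percentage points higher from compound 2 to compound 3 (within the scatter), and methyl in place of chloro at the same place comes out as a number 2.6 percentage points higher from compound 1 to compound 3 (within the scatter). The earlier pair covered only hydrogen and chloro, whereas this place now also carries a carbon group, and none of the steps among the three compounds separates from the scatter, so at this single dose the read-out does not tell hydrogen, chloro and methyl apart. No independent evidence bears on this result.

Going by these compounds, whether a methoxy, an amine or a nitro group on the same carbon would give a step beyond the scatter stays open, and with it the question of whether this place affects the read-out at all. The three compounds also share the rest of the core and are compared at one dose and one time, which leaves open how changes elsewhere on the core would read and how the compounds would compare at other doses.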